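The source may report more compounds than this note shows. Statements on the series, on what has been measured and on what is new or still open speak of the compounds shown alone.

In an ADME assay on HepG2 cells (Homo sapiens) for cytotoxicity (a lower number here means that less compound is tolerated, a higher number that more compound is tolerated), compound 1 `O=C(NC1CCCC1)[C@@H]1CN(c2ccc(C(F)(F)F)cc2)CC(=O)N1c1ccc2ccsc2c1` gives 20000 nM, and compound 2 `O=C(NC1CCCC1)C1CN(c2ccc(C(F)(F)F)cc2)CC(=O)N1c1ccc2ccsc2c1`, the same atoms and bonds drawn without a configuration at the saturated ring carbon, gives 10000 nM. The step is a 2.0-fold lower number from compound 1 to compound 2 (0.30 log units; within the scatter), which lies within the scatter, so compound 2 stands level with compound 1. That step reflects only the fact that one of compounds 1 and 2 is drawn with a defined configuration and the other without, at the place where they differ and does not touch the aromatic group on the amide-type nitrogen in a ring. Compound 3 `O=C(NC1CCCC1)C1CN(c2ccc(C(F)(F)F)cc2)CC(=O)N1c1cnc2ccsc2c1` changes exactly that group: a group of 9 heavy atoms (7 carbon, 1 nitrogen, 1 sulfur; one five-membered aromatic ring with 1 hetero atom, one six-membered aromatic ring with 1 hetero atom) in place of a group of 9 heavy atoms (8 carbon, 1 sulfur; one five-membered aromatic ring with 1 hetero atom, one six-membered aromatic ring of carbon only), on an amide-type nitrogen in a ring. For the measured compounds named here, no measured step bears on this place. With compound 2 at 10000 nM as the only anchor, no step beyond the scatter is expected in this assay. The expected step is a 1.4-fold higher number from compound 2 to compound 3 (0.15 log units; within the scatter). For compound 3 the estimated value is 14000 nM, with an expected range from 6000 nM to 40000 nM.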

Compound 3, half-maximal cytotoxic concentration: 30000 nM
Compound 3: the middle estimate sits 2.1-fold (0.33 log units) below what was measured; measured number inside the range.
By their numbers in this assay, from the lowest: compounds 2, 1 and 3 (each within the scatter of the next, the first and the last beyond it).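

In this assay, the aromatic group on the amide-type nitrogen in a ring is the first place shown where a change goes beyond the scatter. Putting a nitrogen into the six-membered aromatic ring of the 1-benzothiophen-6-yl group, with the heavy-atom count and ring sizes unchanged, gives a 3.0-fold higher number from compound 2 to compound 3 (0.48 log units; beyond the scatter). The step is modest, and nothing measured here accounts for it.

A single replacement at this place leaves open whether the step depends on where the ring nitrogen sits, and whether a plain phenyl or a pyridyl group on the same nitrogen would move the number in the same way. On these data alone, compound 3 is also drawn without a configuration at the saturated ring carbon, so it remains open how its separate S and R forms compare.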